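The source may report more compounds than this note shows. Statements on the series, on what has been measured and on what is new or still open speak of the compounds shown alone.

Working notes on the quinoxaline-fused spirooxindole series. Compound 2 is `N#CC1=C(N)Oc2c(N)cc3nc4ccccc4nc3c2C12C(=O)N(Cc1cnnn1-c1cc(Cl)ccc1Cl)c1ccccc12`. In an ADME assay on HUVEC cells (Homo sapiens) for antiproliferative activity, read by MTT assay, with a stated time of 48 h (a higher number here means a weaker inhibitor, a lower number a stronger inhibitor), compound 2 gives > 50000 nM, a limit of the assay and not a number. Compound 1, `N#CC1=C(N)Oc2c(N)cc3nc4ccccc4nc3c2C12C(=O)N(Cc1cnnn1-c1cccc(Br)c1)c1ccccc12`, carries 3-bromophenyl on the aromatic nitrogen where compound 2 carries 2,5-dichlorophenyl. In this assay compound 1 gives > 50000 nM, again a limit. Among the compounds with values here, the one measured step, a step that the two limits leave unreadable from compound 1 to compound 2, is therefore unreadable in size, and the only evidence on the series is the limit of > 50000 nM in this assay, at which 2 of the 2 values shown sit.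

Compound 3 is `N#CC1=C(N)Oc2c(N)cc3nc4ccccc4nc3c2C12C(=O)N(Cc1cnnn1-c1c(Cl)cc(Cl)cc1Cl)c1ccccc12`. The change from compound 2 is 2,4,6-trichlorophenyl in place of 2,5-dichlorophenyl on an aromatic nitrogen, the third chlorine sitting on the same phenyl ring. Within the data shown here, no measured step resolves a number on either side of this change, and both values sit at the same limit, so no direction can be read from them.

Expectation: compound 3 is estimated to stay at or beyond the limit in this assay, most likely reported as a limit, with 60000 nM spanning 20000 nM to 200000 nM. The step expected is a step that the limit leaves unreadable from compound 2 to compound 3, not beyond the scatter.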

Compound 3, half-maximal inhibitory concentration: 18300 nM
Compound 3: middle estimate off by 3.3-fold (0.52 log units), on the high side, outside the stated range (below it).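

Within the data shown here, replacing the aryl group on the aromatic nitrogen of the five-membered ring gives the first readable change: an at least 2.7-fold lower number from compound 2 to compound 3 (0.43 log units; beyond the scatter), and the same group gives an at least 2.7-fold lower number from compound 1 to compound 3 (0.43 log units; beyond the scatter) in this assay. This place can therefore take a compound of the series off the limit, which compound 1 and compound 2 could not show, their own step being unreadable. The other compounds shown remain at a limit, not a number: the limit of > 50000 nM in this assay, at which 2 of the 3 values shown sit.

Going by these compounds, it remains open whether the lower number follows the third chlorine or the altered arrangement of chlorines, since 2,5-dichlorophenyl and 2,4,6-trichlorophenyl differ in both the count and the placement of these atoms. The compounds shown also leave open how this place responds to a phenyl ring without halogen, or to one carrying an amine or a carboxylic acid, and whether any such group would bring the number lower than in compound 3.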